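The compounds below may be only part of what the source reports. "The series", "measured", "known", "first", "only" and "open" are said of these compounds alone.

Compounds measured so far:
- compound 1 `Cc1c(C(=O)N/N=C/c2ccccc2)no[n+]1[O-]`: > 400000 nM (a limit)
- compound 2 `Cc1c(C(=O)N/N=C/c2ccccn2)no[n+]1[O-]`: > 400000 nM (a limit)

In an ADME assay on J774.1 cells (Mus musculus) for cytotoxicity, read by MTT assay, with a stated time of 48 h (on this read-out higher numbers stand for weaker inhibition and lower numbers for stronger inhibition), compound 1 gives > 400000 nM, which is a limit and not a number. For the measured compounds named here, its exact place on the scale is therefore unknown, and the only other value available for comparison is also a limit. Both results rest on (the limit of > 400000 nM in this assay, at which 2 of the 2 values shown sit).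

The next compound to be tested is compound 3 `Cc1c(C(=O)N/N=C/c2ccc(C(=O)O)cc2)no[n+]1[O-]`. It differs from compound 1 by carboxy in place of hydrogen on an aromatic carbon, with carboxy in place of hydrogen on an aromatic carbon, para to a large group.

Going by the values given here, only one measured step bears on this change: a step that the two limits leave unreadable from compound 1 to compound 2. That step replaces phenyl with pyridin-2-yl, a change at the same aromatic ring, but it gives no size to carry over. With nothing to suggest a shift in either direction, no change beyond the scatter is expected in this assay.

The estimate is therefore a number no higher from compound 1 to compound 3 (the limit leaves the size open), an expected step and not a measured one.

For compound 3 the expected value is 400000 nM.

The estimated range for compound 3 runs from 200000 nM to 800000 nM.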

Compound 3, half-maximal inhibitory concentration: > 300000 nM
Compound 3: no number, only a limit; the forecaster's own chance of this, stated with the estimate: 80%; the middle value does not contradict the limit.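

The results for compound 1 and compound 3 are both limits and not numbers, so no size can be read for the change from one to the other. The compounds shown leave open where each true value lies and whether carboxy in place of hydrogen on an aromatic carbon changes the result in this assay at all.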